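The source may report more compounds than this note shows. Statements on the series, on what has been measured and on what is new or still open speak of the compounds shown alone.

Measured so far in an ADME assay on C8166 cells (Homo sapiens) for cytotoxicity, read by MTT assay; a higher number here means that more compound is tolerated, a lower number that less compound is tolerated:

Compound 1 `O=C(O)c1cc(-c2cccc(OCc3ccccc3)c2)[nH]n1` gives 640000 nM.
Compound 2 `O=C(O)c1cc(-c2ccc([N+](=O)[O-])cc2)[nH]n1` gives > 857000 nM, which is a limit of the assay and not a number.

Going by these compounds, compound 2 thus stands at the limit of > 857000 nM in this assay, at which 1 of the 2 values shown sits, the upper edge of what the assay reports, and its true value is unknown beyond that. Among the measured compounds shown here, compound 1, by contrast, has a measured number, and the two values show only that one compound reached the limit and the other did not.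

Compound 3 `COC(=O)c1cc(-c2ccc([N+](=O)[O-])cc2)[nH]n1` differs from compound 2 by methyl in place of hydrogen on an oxygen next to a carbonyl group. For the measured compounds named here, no pair of measured compounds shows a change of this kind, so there is nothing in these data to size it by. The step from compound 2 to compound 3 is expected to be about an at least 1.2-fold lower number from compound 2 to compound 3 (0.08 log units; that floor lies within the scatter), that is, nothing beyond the usual scatter. Compound 3 is therefore expected to give roughly 700000 nM, somewhere between 150000 nM and 2500000 nM, with a fair chance that this assay again returns only a limit.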

Compound 3, half-maximal cytotoxic concentration: > 809000 nM
Compound 3 gave a limit, no number; the forecaster's own chance of this, stated with the estimate: 50%; at least 1.1-fold (0.06 log units) between middle value and limit.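

Among the compounds shown here, compound 2 and compound 3 each returned only a limit of the assay and not a number, so no step between them can be read. Going by these compounds, whether methyl in place of hydrogen on this oxygen changes how much compound is tolerated, and by how much, stays open.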